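The compounds below may be only part of what the source reports. "The series", "measured", "known", "first", "only" and "open" are said of these compounds alone.

For the measured compounds named here, compound 1 `Nc1ccccc1NC(=O)c1ccc(CSC(=S)N2CCN(c3ccccc3)CC2)cc1` stands highest of the three numbers measured so far: in a functional assay on MGC-803 cells (Homo sapiens) for antiproliferative activity, read by CCK-8 assay, with a stated time of 72 h, tested at 2 uM (on this read-out lower numbers stand for a weaker effect and higher numbers for a stronger effect at the one concentration tested), compound 1 gives 42.3%. Compound 3 `Nc1ccccc1NC(=O)c1ccc(CSC(=S)N2CCc3ccc([N+](=O)[O-])cc32)cc1` comes nearest, giving 30.6% in this assay, a gap that lies beyond the scatter. Compound 2 `CC1CCN(C(=S)SCc2ccc(C(=O)Nc3ccccc3N)cc2)CC1` is furthest, giving 28.1% in this assay, again beyond the scatter. Going by the values given here, no pair of measured compounds differs in a single place, so no measured step guides the next comparison. Compound 4 `Nc1ccccc1NC(=O)c1ccc(CSC(=S)N2CCN(Cc3ccccc3)CC2)cc1` differs from compound 1 by benzyl in place of phenyl on an amine nitrogen in a ring. Among the compounds with values here, with only three numbers and no comparable step, the change is expected to move the read-out little, and the step of a number 4.3 percentage points lower from compound 1 to compound 4 (within the scatter) is estimated to stay within the scatter. Compound 4 is therefore expected to give about 38%, within a range from 22% to 55%.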

Compound 4, a percentage reported as inhibition, at one concentration (the size of the read-out at that concentration, not a potency): 18.1%
Compound 4: middle estimate off by 19.9 percentage points, on the high side, and the stated range ends above it.
By their numbers in this assay, from the lowest: compounds 4, 2 and 3 (each within the scatter of the next, the first and the last beyond it); then compound 1.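

Benzyl in place of phenyl on an amine nitrogen in a ring gives a number 24.2 percentage points lower from compound 1 to compound 4 (beyond the scatter) in this assay. For the compounds shown here, this is the first measured step at this position, and it shows that the read-out responds to the group on that nitrogen even though both groups carry the same aromatic ring. No measured evidence bears on the reason for this drop.

The compounds shown leave open whether a pyridine ring or a phenethyl group on that nitrogen would match compound 1 or fall further, and whether a methoxy group on the phenyl would change its number.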